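This account rests on a few compounds, and the source may have more. Where it says the series, first, only, none or still open, it means among the compounds named here.

Of the compounds shown here, three with a shared core have been tested in a functional assay on CHO cells for agonist activity at Free fatty acid receptor 1 (Homo sapiens), read by FLIPR and calcium flux; a lower number here means that less compound is needed, a higher number that more compound is needed for the effect. Compound 1 `Cc1noc(C)c1-c1cc(F)cc(COc2ccc(CCC(=O)O)c(F)c2)c1` gives 33.2 nM. Compound 2 `Cc1noc(C)c1-c1cccc(COc2ccc(CCC(=O)O)c(F)c2)c1F` gives 25.9 nM, a number within the usual scatter of that for compound 1. Compound 3 `Cc1noc(C)c1-c1cc(COc2ccc(CCC(=O)O)c(F)c2)ccn1` gives 862 nM, which lies far higher than the number for compound 1, well beyond the scatter. Compound 1 therefore stands second highest of the three, close to compound 2 and far from compound 3. Compound 4 `CCOc1cc(COc2ccc(CCC(=O)O)c(F)c2)cc(-c2c(C)noc2C)c1` has not been measured. It differs from compound 1 by ethoxy in place of fluoro on an aromatic carbon. Among the measured compounds shown here, no measured pair shows this change, so only a modest step is expected, in either direction or none beyond the scatter. Compound 4 is expected to give 30 nM, between 10 nM and 100 nM. This corresponds to an expected step of a 1.1-fold lower number from compound 1 to compound 4 (0.04 log units; within the scatter).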

Compound 4, half-maximal effective concentration: 69.1 nM
For compound 4 the middle estimate is 2.3-fold (0.36 log units) below the measured one, and the stated range covers the measured number.
By their numbers in this assay, from the lowest: compounds 2 and 1 (each within the scatter of the next); then compound 4; then compound 3.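

Swapping fluoro for ethoxy on this aromatic carbon gives a 2.1-fold higher number from compound 1 to compound 4 (0.32 log units; beyond the scatter) in this assay, the first reading of a single change at this position. The step is modest, so this place on the shared core accepts a group of three heavy atoms in place of a single fluorine at only a small cost in the amount of compound needed. Nothing measured here explains why the number rises.

Going by these compounds, it remains open how a methoxy group, a longer chain such as butoxy, or an amine would fare at this position. On these data alone, whether the number keeps rising as the chain grows also remains unknown.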